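Imidazole substituent exchange: cyanobenzyl to tert-butyl in compound 4

This account rests on a few compounds, and the source may have more. Where it says the series, first, only, none or still open, it means among the compounds named here.

Three compounds sharing the biphenyl carboxylic acid and imidazole core have been run in an in vitro functional assay on cells for agonist activity at Bombesin receptor subtype-3 (Homo sapiens), read by luminescence and calcium flux; a lower number here means that less compound is needed, a higher number that more compound is needed for the effect. Compound 1 `CCCCc1cnc(C(C)Cc2ccc(-c3ccccc3C(=O)O)cc2)[nH]1` gives 2760 nM and compound 2 `CCCCc1cnc(C(CCCC)Cc2ccc(-c3ccccc3C(=O)O)cc2)[nH]1` gives 2660 nM; the step of a 1.0-fold lower number from compound 1 to compound 2 (0.02 log units; within the scatter) shows that extending the chain branch changes nothing beyond the scatter. Compound 3 `N#Cc1ccc(Cc2cnc(CCc3ccc(-c4ccccc4C(=O)O)cc3)[nH]2)cc1` gives 5890 nM, the highest number of the three, beyond the scatter from both compound 1 and compound 2.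

Compound 4 `CC(C)(C)c1cnc(CCc2ccc(-c3ccccc3C(=O)O)cc2)[nH]1` is not yet measured. It differs from compound 3 by tert-butyl in place of 4-cyanobenzyl on an aromatic carbon. Within the data shown here, no measured step addresses this exact change; the only measured step, a 1.0-fold lower number from compound 1 to compound 2 (0.02 log units; within the scatter), concerns a different position and is within the scatter. Compounds 1 and 2 carry a butyl group on the same ring carbon and sit lower than compound 3, so a smaller saturated group there may bring compound 4 back toward their range, though the chain branch of compound 1 and compound 2 is absent in compound 4. Compound 4 is therefore expected near 3000 nM, in the range 1200 nM to 8000 nM. The expected step is a 2.0-fold lower number from compound 3 to compound 4 (0.29 log units; within the scatter), a modest move toward a lower number, close to the edge of the scatter.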

Compound 4, half-maximal effective concentration: 4330 nM
Beside the measured number, compound 4's estimate is 1.4-fold (0.16 log units) below it, and the stated range covers the measured number.
By their numbers in this assay, from the lowest: compounds 2, 1, 4 and 3 (each within the scatter of the next, the first and the last beyond it).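

Among these compounds, the step of a 1.4-fold lower number from compound 3 to compound 4 (0.13 log units; within the scatter) is the first reading at this place, on an aromatic carbon of a five-membered aromatic ring with 2 nitrogen, in this assay; the earlier step concerned only the saturated chain. Within the scatter, this place takes tert-butyl as it takes 4-cyanobenzyl, even though the exchange removes the six-membered aromatic ring, the triple bond and the hydrogen-bond acceptor of the leaving group. No supporting data are available to explain this outcome.

Open, going by these compounds, is whether an amine or a hydroxyl group at this place would give a number beyond the scatter of compound 3 and compound 4. Also open, on these data alone, is whether a chain branch like that of compound 1 would matter alongside tert-butyl on the ring.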